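A few compounds are considered here, and "the series" means these few. Any claim that something is new, unique, unknown or untested is made for them only; others in the source may bear on it.

Working notes on a short series of esters sharing a bicyclic core with a cytotoxicity read-out.

Compound 1 `COc1ccc(C(=O)O[C@H]2C=C(C)C(=O)C[C@@]3(C)CC[C@@](O)(C(C)C)[C@H]23)cc1` and compound 2 `CC1=C[C@H](OC(=O)c2ccc(O)cc2)[C@@H]2[C@](C)(CC[C@@]2(O)C(C)C)CC1=O` share the same core and differ only in the aryl ester. In a functional assay on SEM cells (Homo sapiens) for cytotoxicity, read by MTT assay, with a stated time of 72 h (a higher number here means a weaker inhibitor, a lower number a stronger inhibitor), compound 1 gives 28400 nM. In this assay compound 2 gives 24400 nM. The change between them, (hydrogen in place of methyl on an oxygen on an aromatic ring), produced a 1.2-fold lower number from compound 1 to compound 2 (0.07 log units; within the scatter).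

Compound 3 `COc1ccc(C(=O)O[C@H]2CC(C)=CC[C@@]3(C)CC[C@@](O)(C(C)C)[C@H]23)cc1` carries the same 4-methoxyphenyl ester on a different core; the difference between the core of compound 1 and the core of compound 3 is not broken down here. In this assay compound 3 gives 18200 nM. Its number sits within the scatter of both compound 1 and compound 2, so no order among these three can be claimed.

Compound 4 `CC1=CC[C@@]2(C)CC[C@@](O)(C(C)C)[C@@H]2[C@@H](OC(=O)c2ccc(O)cc2)C1` is the not-yet-measured partner of compound 3. It differs from compound 3 by hydrogen in place of methyl on an oxygen on an aromatic ring, the same change already seen from compound 1 to compound 2, at a place described in identical words. Since that earlier step was within the scatter, the expectation for this assay is a step of similar size, a 1.2-fold lower number from compound 3 to compound 4 (0.08 log units; within the scatter), which is estimated rather than measured. For compound 4 the expected value in this assay is therefore 15000 nM, with a likely range from 7000 nM to 32000 nM, resting on the value of compound 3 and on the earlier step of a 1.2-fold lower number from compound 1 to compound 2 (0.07 log units; within the scatter).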

Compound 4, half-maximal inhibitory concentration: > 100000 nM
Compound 4: a limit, no number; the forecaster's own chance of this, stated with the estimate: 5%; middle value at least 6.6-fold (0.82 log units) from the limit.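

Compound 4 stands at a limit of the assay, not at a number: the limit of > 100000 nM in this assay, at which 1 of the 4 values shown sits.

In this assay the change from 4-methoxyphenyl to 4-hydroxyphenyl gives an at least 5.4-fold higher number from compound 3 to compound 4 (0.73 log units; beyond the scatter), whereas on the core of compound 1 the same change gives a 1.2-fold lower number from compound 1 to compound 2 (0.07 log units; within the scatter), so in this series the step seen on one core does not carry over to the other: the same change on two cores in this assay, a 1.2-fold lower number (0.07 log units; within the scatter) from compound 1 to compound 2 and an at least 5.4-fold higher number (0.73 log units; beyond the scatter) from compound 3 to compound 4, at least 6.3-fold (0.80 log units) apart, beyond the scatter of two such steps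

From the compounds shown here alone, this comparison rests on a single pair for each core, and one of the two steps ends at a limit, so the full size of the step from compound 3 to compound 4 stays unknown and the data do not identify which difference between the two cores goes with the divergence.

The compounds shown leave open whether an amine or a carboxylic acid in place of the methoxy group, or a longer chain in place of the methyl on the oxygen, would track the small step on the core of compound 1 or the large step on the core of compound 3. Also open, going by these compounds, is how the hydroxy and methoxy pair would behave on any core other than these two.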